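Chloro for Carbamoyl at the Cytotoxicity Limit

The compounds below may be only part of what the source reports. "The series", "measured", "known", "first", "only" and "open" are said of these compounds alone.

Of the compounds shown here, three sharing one core have been tested in an ADME assay on 2209-23 cells (Homo sapiens) for cytotoxicity, read by WST assay and thymidine incorporation; on this read-out lower numbers stand for higher toxicity in this test and higher numbers for lower toxicity in this test. Compound 1 `CC(C)(C)[C@H]1C(O)=C(C2=C(C#N)S(=O)(=O)c3cc(NS(C)(=O)=O)ccc3N2)C(=O)N1Cc1ccc(F)cc1` carries a cyano group; in this assay compound 1 gives > 50000 nM, which is a limit of the assay and not a number. Compound 2 `CC(C)(C)[C@H]1C(O)=C(C2=C(C(N)=O)S(=O)(=O)c3cc(NS(C)(=O)=O)ccc3N2)C(=O)N1Cc1ccc(F)cc1` carries a carbamoyl group instead; in this assay compound 2 gives > 50000 nM, again a limit. Compound 3 `CC(C)(C)[C@H]1C(O)=C(C2=CS(=O)(=O)c3cc(NS(C)(=O)=O)cc(F)c3N2)C(=O)N1Cc1ccc(F)cc1` differs in other places; in this assay compound 3 gives > 50000 nM, also a limit. Among the measured compounds shown here, the only measured single-point step, a step that the two limits leave unreadable from compound 1 to compound 2, cannot be read because the limit of > 50000 nM in this assay, at which 3 of the 3 values shown sit, holds both of its ends. Compound 2 therefore stands at the limit, alongside every other value shown, and no number separates any of them.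

The new compound 4 `CC(C)(C)[C@H]1C(O)=C(C2=C(Cl)S(=O)(=O)c3cc(NS(C)(=O)=O)ccc3N2)C(=O)N1Cc1ccc(F)cc1` differs from compound 2 in one place: chloro in place of carbamoyl on a double-bonded ring carbon. For the measured compounds named here, no measured step bears on this change, since the one step with a single change is unreadable, so no direction can be drawn from the data. With all three values at the limit, compound 4 is expected to remain at or beyond it. For compound 4 the expected step is a step that the limit leaves unreadable from compound 2 to compound 4, within the scatter. Compound 4 is thus estimated to give 60000 nM, with a range from 25000 nM to 150000 nM.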

Compound 4, half-maximal cytotoxic concentration: > 50000 nM
Compound 4: no number, only a limit (the forecaster's own chance of this, stated with the estimate: 85%); the middle value does not contradict the limit.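

Neither step to compound 4, from compound 1 or from compound 2, can be read, because these compounds give a limit and not a number: the limit of > 50000 nM in this assay, at which 4 of the 4 values shown sit.

The compounds shown leave open how toxic each one is in this assay and whether chloro, cyano and carbamoyl differ there at all.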